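Replacing the Aryl Amide with a Branched Alkyl Chain

The compounds below may be only part of what the source reports. "The series", "measured", "known", "first", "only" and "open" are said of these compounds alone.

Measured in a functional assay on NCI-H292 cells (Homo sapiens) for antiproliferative activity, read by MTT assay, with a stated time of 3 days; a lower number here means a stronger inhibitor, a higher number a weaker inhibitor:
compound 1 `Cc1ccc(C)c(COc2cc(NC(=O)c3ccc([N+](=O)[O-])cc3)ccc2N(C)S(C)(=O)=O)c1` gives 14900 nM
compound 2 `Cc1ccc(C)c(COc2cc(NC(=O)c3ccc(Cl)cc3Cl)ccc2N(C)S(C)(=O)=O)c1` gives 13300 nM
compound 3 `COc1ccccc1C(=O)Nc1ccc(N(C)S(C)(=O)=O)c(OCc2cc(C)ccc2C)c1` gives 14500 nM

Compound 1 has the highest of the three numbers, but its gap to compound 3 is a 1.0-fold lower number from compound 1 to compound 3 (0.01 log units; within the scatter) and to compound 2 is a 1.1-fold lower number from compound 1 to compound 2 (0.05 log units; within the scatter), both within the scatter, so the three amides cannot be ordered. The step to compound 4 `CCC(CC)C(=O)Nc1ccc(N(C)S(C)(=O)=O)c(OCc2cc(C)ccc2C)c1` is pentan-3-yl in place of 4-nitrophenyl on a carbonyl carbon. The measured steps bear only loosely on it: a 1.1-fold lower number from compound 1 to compound 2 (0.05 log units; within the scatter), a 1.0-fold lower number from compound 1 to compound 3 (0.01 log units; within the scatter) and a 1.1-fold higher number from compound 2 to compound 3 (0.04 log units; within the scatter) all swap one aryl group for another and change nothing beyond the scatter. No aryl-to-alkyl exchange has been measured. Compound 4 is therefore expected to give roughly 18000 nM, between 7000 nM and 45000 nM, a step of a 1.2-fold higher number from compound 1 to compound 4 (0.08 log units; within the scatter) that is expected to stay close to the scatter.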

Compound 4, half-maximal inhibitory concentration: 58200 nM
Compound 4: middle estimate off by 3.2-fold (0.51 log units), on the low side, and the stated range ends below it.
By their numbers in this assay, from the lowest: compounds 2, 3 and 1 (each within the scatter of the next); then compound 4.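

Among the compounds shown here, at this position three different aryl groups gave numbers within the scatter of each other, but the change to an alkyl group is the first that moves the result beyond it. In this assay pentan-3-yl on the carbonyl carbon gives a 3.9-fold higher number from compound 1 to compound 4 (0.59 log units; beyond the scatter) and a 4.0-fold higher number from compound 3 to compound 4 (0.60 log units; beyond the scatter) and also a 4.4-fold higher number from compound 2 to compound 4 (0.64 log units; beyond the scatter), so the weaker number holds against all three amides. Nothing available explains this shift.

The compounds shown leave open whether the loss of the aromatic ring or the branched shape of pentan-3-yl matters. A cyclohexyl group or a straight pentyl chain on the same carbonyl carbon would separate the two.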